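A few compounds are considered here, and "the series" means these few. Any claim that something is new, unique, unknown or untested is made for them only; others in the source may bear on it.

Values in an ADME assay on RAW264.7 cells (Mus musculus) for cytotoxicity, read by MTT assay; on this read-out lower numbers stand for stronger inhibition and higher numbers for weaker inhibition:
Compound 1 `COc1ccc(C(=O)/C=C/C=C/c2ccccc2)cc1`: > 100000 nM
Compound 2 `O=C(/C=C/C=C/c1ccccc1)c1ccc(F)cc1`: "not determined" (no result reported)
Compound 3 `COc1ccc(/C=C/C=C/C(=O)c2ccc(F)cc2)cc1`: "not determined" (no result reported)

Compound 3 has no single number to stand on, since its entry reads "not determined" (no result reported). Compound 2 is in the same position, with "not determined" (no result reported). The only other entry belongs to compound 1, which gives > 100000 nM, and this is a limit of the assay and not a number.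

The next compound to be tested is compound 4 `COc1ccc(/C=C/C=C/C(=O)c2ccco2)cc1`. In it, furan-2-yl takes the place of 4-fluorophenyl on a carbonyl carbon: furan-2-yl in place of 4-fluorophenyl on a carbonyl carbon.

Within the data shown here, no measured step exists to show what such a swap does in this assay, and compound 3 offers no starting number. The expectation is therefore of no step beyond the scatter, in either direction. The nearest guide is compound 1 at > 100000 nM, so a reading near that limit is expected.

For compound 4 the estimated value is 70000 nM, with an expected range of 20000 nM to 150000 nM.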

Compound 4, half-maximal inhibitory concentration: 76600 nM
Estimate against measurement, compound 4: 1.1-fold (0.04 log units) below; measured number inside the range.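

No step can be read from compound 3 to compound 4: compound 3 has no single number in this assay while compound 4 gives 76600 nM there. Going by these compounds, what furan-2-yl in place of 4-fluorophenyl on a carbonyl carbon does in this assay stays open.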